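This account rests on a few compounds, and the source may have more. Where it says the series, first, only, none or still open, it means among the compounds named here.

In a functional assay on A-375 cells (Homo sapiens) for antiproliferative activity (on this read-out lower numbers stand for stronger inhibition and higher numbers for weaker inhibition), compound 1 `O=C(Nc1ccc(-c2ccccc2)cc1)C1CCCN(Cc2ccc(F)c(F)c2)C1` gives 2580 nM and compound 2 `O=C(Nc1ccc(-c2ccoc2)cc1)C1CCCN(Cc2ccc(F)c(F)c2)C1` gives 1290 nM on a shared core. Among the compounds with values here, these are the only two numbers available, and compound 2 stands within the scatter of compound 1, so the two cannot be ranked. Compound 3 `O=C(Nc1ccc(-c2ccco2)cc1)C1CCCN(Cc2ccc(F)c(F)c2)C1` has not yet been measured. It differs from compound 2 in one group only: furan-2-yl in place of furan-3-yl on an aromatic carbon and in words this is furan-2-yl in place of furan-3-yl on an aromatic carbon. The same atoms are simply joined differently. Within the data shown here, only one measured step bears on this change, a 2.0-fold lower number from compound 1 to compound 2 (0.30 log units; within the scatter) and it sits on the same aromatic carbon, where furan-3-yl took the place of phenyl. Among the measured compounds shown here, that step stays inside the scatter, and no measured compound shows what a change of furan attachment does. No step beyond the scatter is therefore expected in this assay and no direction can be favoured. The estimated change is a 1.2-fold higher number from compound 2 to compound 3 (0.07 log units; within the scatter) and it is expected to stay within the scatter. Compound 3 is estimated at 1500 nM with an expected range from 600 nM to 3500 nM for repeated measurements.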

Compound 3, half-maximal inhibitory concentration: 1040 nM
Estimate against measurement, compound 3: 1.4-fold (0.16 log units) above, within the range that was stated.
By their numbers in this assay, from the lowest: compounds 3, 2 and 1 (each within the scatter of the next, the first and the last beyond it).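

In this assay, putting furan-2-yl in place of furan-3-yl gives a 1.2-fold lower number from compound 2 to compound 3 (0.09 log units; within the scatter), so on this aromatic carbon, para to a large group, the two furan attachments cannot be told apart, even though the same atoms are simply joined differently. Within the data shown here, putting furan-2-yl in place of phenyl gives a 2.5-fold lower number from compound 1 to compound 3 (0.39 log units; beyond the scatter), a modest step but the first at this position to lie beyond the scatter, whereas the step with furan-3-yl, a 2.0-fold lower number from compound 1 to compound 2 (0.30 log units; within the scatter), stays inside it, so the three compounds show only that a five-membered aromatic ring can be set here with a modest difference from phenyl at best. Nothing measured here accounts for this difference.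

The compounds shown leave open how other rings would read at this position, such as thiophen-2-yl or pyridin-3-yl, and whether a methyl group or an amine carried on the furan would move the number beyond the scatter of compound 3. They also leave open how far the rest of the shared core, which is the same in all three compounds, takes part in this activity.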